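Aminophenyl to Difluorophenyl on a Chalcone-Type Carbonyl

This account rests on a few compounds, and the source may have more. Where it says the series, first, only, none or still open, it means among the compounds named here.

Measured compounds:
Compound 1 `COc1ccc(-c2cc(/C=C/C(=O)c3ccc(N)cc3)[nH]n2)cc1` gives 105% in a functional assay on OVCAR-4 cells (Homo sapiens) for cytotoxicity, read by sulforhodamine B assay, with a stated time of 48 h, tested at 0.1 uM; on this read-out lower numbers stand for a stronger effect and higher numbers for a weaker effect at the one concentration tested.
Compound 2 `COc1cc(-c2cc(/C=C/C(=O)c3ccc(N)cc3)[nH]n2)cc(OC)c1OC` gives 105% in this assay.

On the numbers shown, compound 2 stands level with compound 1 at the digits printed, and the two values lie within the usual scatter of each other, so nothing can be said of any order between them. At the single concentration tested, neither compound 1 nor compound 2 shows a measurable reduction in this assay.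

Compound 3 `COc1cc(-c2cc(/C=C/C(=O)c3ccc(F)c(F)c3)[nH]n2)cc(OC)c1OC` is the next compound to be considered. It differs from compound 2 in one place: 3,4-difluorophenyl in place of 4-aminophenyl on a carbonyl carbon.

Among the compounds with values here, no step between measured compounds is known that would show how this kind of change acts in this assay, so any expectation rests on compound 2 alone. Because compound 2 gives 105% at this concentration, compound 3 is expected to show no step beyond the scatter, a number 5 percentage points lower from compound 2 to compound 3 (within the scatter). The estimate for compound 3 is 100%, with a range from 85% to 115%.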

Compound 3, a percentage reported as activity, at one concentration (the size of the read-out at that concentration, not a potency): 111%
Compound 3: middle estimate off by 11 percentage points, on the low side, within the range that was stated.
By their numbers in this assay, from the lowest: compounds 1, 2 and 3 (each within the scatter of the next).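

The exchange of 4-aminophenyl for 3,4-difluorophenyl on a carbonyl carbon gives a number 6 percentage points higher from compound 2 to compound 3 (within the scatter) in this assay at the one concentration tested. Within the data shown here, this is the first view of that position, as compounds 1 and 2 differ elsewhere, and it shows that a group counted with no hydrogen-bond donor or acceptor and one counted with one of each cannot be told apart by this read-out at this concentration, with neither compound 2 nor compound 3 showing a measurable reduction. Nothing available bears on why the read-out stays where it does.

Among these compounds, with no compound here showing an effect in this test, the three say nothing about which groups on the carbonyl carbon might produce one, and it stays open whether a smaller or a charged group there, such as a carboxylic acid or a dimethylamine on the phenyl ring, would lower the number. Going by these compounds, it also stays open whether the compounds would separate at a higher concentration, and whether 3,4-difluorophenyl would read the same on the core of compound 1.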